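A few compounds are considered here, and "the series" means these few. Any claim that something is new, unique, unknown or untested is made for them only; others in the source may bear on it.

Compound 1 `COc1cc(/C=C/C(=O)c2sc(Nc3ccc(Cl)cc3)nc2C)cc(OC)c1OC` was tested in a functional assay on BGC-823 cells (Homo sapiens) for cytotoxicity, read by MTT assay; a lower number here means a stronger inhibitor, a higher number a weaker inhibitor. In this assay compound 1 gives only > 25000 nM, which is a limit of the assay rather than a number. Two companions were tested alongside it. Compound 2 `Cc1nc(Nc2cccc(Cl)c2)sc1C(=O)/C=C/c1ccccc1` gives > 25000 nM in this assay, again a limit. Compound 3 `Cc1ccc(Nc2nc(C)c(C(=O)/C=C/c3ccccc3Cl)s2)cc1` gives > 25000 nM in this assay, also a limit. So every value shown sits at the limit of > 25000 nM in this assay, at which 3 of the 3 values shown sit, and none of the three compounds reaches a measurable inhibition.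

The next compound, compound 4 `COc1cc(/C=C/C(=O)c2sc(Nc3cccc(C)c3)nc2C)cc(OC)c1OC`, keeps the core of compound 1 and changes one group: 3-methylphenyl in place of 4-chlorophenyl on a nitrogen on an aromatic ring. Among the compounds with values here, no step between two measured compounds is available, so the size of this change cannot be read off a measured pair. With all three shown compounds at the limit, no movement beyond the usual scatter is expected from compound 1 to compound 4 in this assay, and the step that the limit leaves unreadable from compound 1 to compound 4 is expected to be essentially none. Compound 4 is therefore estimated at 30000 nM in this assay, with a range from 10000 nM to 100000 nM, most likely reported again as a limit.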

Compound 4, half-maximal inhibitory concentration: 17200 nM
Compound 4: the middle estimate sits 1.7-fold (0.24 log units) above what was measured; low and high end bracket the measured number.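

In this assay, within the data shown here, compound 4 gives 17200 nM, the first measured number in this set, so a compound with this core can give a reading on this scale when 3-methylphenyl sits on the nitrogen in place of 4-chlorophenyl. The step reads an at least 1.4-fold lower number from compound 1 to compound 4 (0.16 log units; that floor lies within the scatter). Compound 1 is only a limit, so the real size of this change cannot be told, and the same limit still holds most of the set: the limit of > 25000 nM in this assay, at which 3 of the 4 values shown sit.

On these data alone, it stays open which part of the change matters: losing the chlorine, gaining the methyl, or moving the group around the ring, as 3-chlorophenyl and 4-methylphenyl appear here only on compounds that also differ elsewhere. Also open, as far as these compounds go, is how a phenyl ring carrying an amine or a carboxylic acid would behave at this position.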